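A few compounds are considered here, and "the series" means these few. Any claim that something is new, unique, unknown or untested is made for them only; others in the source may bear on it.

Measured so far in a functional assay on NCI-H460 cells (Homo sapiens) for inhibition, read by sulforhodamine B assay, with a stated time of 48 h, tested at 0.1 uM; on this read-out lower numbers stand for a stronger effect and higher numbers for a weaker effect at the one concentration tested:
Compound 1 `O=C(Nc1cccc(-n2cc(-c3ccncc3)c(-c3cc(O)cc(Cl)c3)n2)c1)Nc1ccc(Cl)c(C(F)(F)F)c1` gives 102%.
Compound 2 `O=C(Nc1cccc(-n2cc(-c3ccncc3)c(-c3cc(O)cc(Cl)c3)n2)c1)Nc1ccc(Cl)c(Cl)c1` gives 97%.
Compound 3 `COc1cc(Cl)cc(-c2nn(-c3cccc(NC(=O)Nc4cc(C(F)(F)F)cc(C(F)(F)F)c4)c3)cc2-c2ccncc2)c1` gives 101%.

Compound 3 stands second highest of the three numbers, nearest to compound 1 and furthest from compound 2, and both gaps lie within the scatter, so the three compounds cannot be told apart on this read-out; all of them sit where no inhibition is seen. Compound 4 `COc1cc(Cl)cc(-c2nn(-c3cccc(NC(=O)Nc4cccc(C(F)(F)F)c4)c3)cc2-c2ccncc2)c1` differs from compound 3 in one place: hydrogen in place of trifluoromethyl on an aromatic carbon. Going by the values given here, the one measured step, a number 5 percentage points lower from compound 1 to compound 2 (within the scatter), also concerns a substituent on an aromatic carbon of the same part of the shared core and lies within the scatter. Nothing in the measured compounds shows a change of this kind moving the read-out. Compound 4 is therefore expected to sit where compound 3 sits, with a step of a number 1 percentage points lower from compound 3 to compound 4 (within the scatter) and no movement beyond the scatter. The estimate for compound 4 is 100%, with a range from 88% to 112%.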

Compound 4, a percentage reported as activity, at one concentration (the size of the read-out at that concentration, not a potency): 102%
Compound 4: middle estimate off by 2 percentage points, on the low side; the range from low to high includes it.
By their numbers in this assay, from the lowest: compounds 2, 3, 1 and 4 (each within the scatter of the next).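

In this assay, hydrogen in place of trifluoromethyl on this aromatic carbon gives a number 1 percentage points higher from compound 3 to compound 4 (within the scatter). The earlier step exchanged one substituent for another, whereas this one removes the substituent altogether, and the read-out still shows no change beyond the scatter; at this single concentration, then, the trifluoromethyl group at this position is not needed to keep the number where it stands, though with no inhibition seen for compound 3 there was no effect here to lose. No measured evidence is available that would explain this result.

From the compounds shown here alone, it remains open whether an amine or a carboxylic acid on this aromatic carbon would bring the number down. Also open, going by these compounds, is whether hydrogen in place of the remaining trifluoromethyl group of compound 4 would move the read-out.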